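The compounds below may be only part of what the source reports. "The series", "measured", "known", "first", "only" and "open" are said of these compounds alone.

Measured so far:
Compound 1, `O=Cc1c(-c2ccccc2)sc2ccccc12`: 42%
Compound 2, `N#Cc1c(-c2cccc(Cl)c2)sc2ccccc12`: 23%

Both were tested in a functional assay on KB cells (Homo sapiens) for cytotoxicity, tested at 10 uM; on this read-out lower numbers stand for less inhibition and higher numbers for more inhibition at the one concentration tested (going by the name of the read-out). Compound 1 gives 42%, while compound 2 gives 23%, the lower of the two numbers; its nearest neighbour, compound 1, stands higher by a gap that goes beyond the usual scatter. These two compounds differ in two places at once, so the gap cannot be tied to a single change.

Compound 3, `N#Cc1c(-c2ccccc2)sc2ccccc12`, differs from compound 2 in one place: hydrogen in place of chloro on an aromatic carbon. For the measured compounds named here, no measured pair shows this change on its own, so its effect in this assay is unknown. Compound 1 also carries an unsubstituted ring, but a different group where compound 3 has its nitrile, so it offers only a loose hint. A small step is expected, upward if at all and likely within the scatter: the expected step is a number 5 percentage points higher from compound 2 to compound 3 (within the scatter). Compound 3 is therefore estimated at 28%, with a range from 10% to 48%.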

Compound 3, a percentage reported as inhibition, at one concentration (the size of the read-out at that concentration, not a potency): 42%
Beside the measured number, compound 3's estimate is 14 percentage points below it; the measured number falls inside the stated range.
By their numbers in this assay, from the lowest: compound 2; then compounds 1 and 3 (each within the scatter of the next).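

Hydrogen in place of chloro on an aromatic carbon, meta to a large group, gives a number 19 percentage points higher from compound 2 to compound 3 (beyond the scatter) in this assay, so in this pair the compound with the chloro shows less inhibition at the one concentration tested. Cyano in place of formyl on an aromatic carbon gives no change at the digits printed from compound 1 to compound 3 (within the scatter), so with the unsubstituted ring these two groups cannot be told apart on this read-out. For the compounds shown here, of these two single changes, only the one at the chloro position gives a step beyond the scatter.

From the compounds shown here alone, whether other groups at that place, such as a methyl or an amine, would behave like the chloro or like hydrogen stays open, as does the effect of a carboxylic acid where the nitrile sits. No measurement at hand explains the step seen with the chloro.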